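The compounds below may be only part of what the source reports. "The series", "measured", "known", "first", "only" and "open" are said of these compounds alone.

Going by the values given here, compound 2, with the structure `c1ccc(-c2cn[nH]c2)c(NCC2=NCCN2)c1`, gives 72% in a functional assay with Alpha-1B adrenergic receptor (Homo sapiens) as the target, read by calcium flux (a higher number here means a larger maximal response, a lower number a smaller maximal response), the highest of the two values known so far. Among the compounds with values here, its only neighbour is compound 1, with the structure `CCn1ccc(-c2ccccc2NCC2=NCCN2)n1`, which gives 0% in this assay, a figure that lies beyond the scatter below compound 2.

The step to compound 3, whose structure is `Cn1ccc(-c2ccccc2NCC2=NCCN2)n1`, alters the group carried on the aromatic carbon of the six-membered aromatic ring of carbon only, ortho to a group of 7 heavy atoms: 1-methyl-1H-pyrazol-3-yl in place of 1H-pyrazol-4-yl on an aromatic carbon. The hydrogen-bond donor of the 1H-pyrazol-4-yl is gone and a second hydrogen-bond acceptor is present in its place.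

Within the data shown here, no step between two measured compounds matches this change, so the direction must be judged from the two known values. Compound 3 is expected to fall well below compound 2, with a step of a number 62 percentage points lower from compound 2 to compound 3 (beyond the scatter), because compound 1, whose structure `CCn1ccc(-c2ccccc2NCC2=NCCN2)n1` closely resembles that of the unmeasured compound, gives 0%. For compound 3 the estimated maximal response is 10%, within a range from 0% to 40%.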

Compound 3, largest response reached (reported as maximal response), in percent of the reference or control that the assay uses: 33%
The estimate for compound 3 lay 23 percentage points below the measured number; measured number inside the range.
By their numbers in this assay, from the lowest: compound 1; then compound 3; then compound 2.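

In this assay, 1-methyl-1H-pyrazol-3-yl in place of 1H-pyrazol-4-yl on an aromatic carbon of the six-membered aromatic ring gives a number 39 percentage points lower from compound 2 to compound 3 (beyond the scatter), so this exchange lowers the maximal response without abolishing it. The result also shows that the response at this position depends on the chain carried on the aromatic nitrogen of the pyrazole: hydrogen in place of methyl on the saturated chain carbon bound to that nitrogen gives a number 33 percentage points higher from compound 1 to compound 3 (beyond the scatter), a large step from a single carbon's difference in the chain. No measurement of any property of these compounds bears on either step.

The step from compound 2 to compound 3 changes both the point of attachment of the pyrazole and the substituent on its nitrogen, so the compounds shown cannot separate these two contributions; the 1-methyl-1H-pyrazol-4-yl and 1H-pyrazol-3-yl groups would do so. On these data alone, whether the response falls further with a propyl chain on the aromatic nitrogen, or how a hydroxyethyl chain there would compare, also remains open.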